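Compound 3: a benzothiazolyl group replaces a nitrile

The source may report more compounds than this note shows. Statements on the series, on what has been measured and on what is new or still open speak of the compounds shown alone.

Measured in a functional assay on HeLa cells (Homo sapiens) for antiproliferative activity, read by MTT assay, with a stated time of 48 h; a higher number here means a weaker inhibitor, a lower number a stronger inhibitor:
- compound 1 `CN(C)CCCCn1c(N)c(C#N)c2nc(C#N)c(C#N)nc21`: > 50000 nM (a limit)
- compound 2 `N#Cc1nc2c(-c3nc4ccccc4o3)c(N)n(CCCN3CCCCC3)c2nc1C#N`: 12200 nM

Compound 1 is known only as a limit, > 50000 nM, and not as a number. Compound 3 `CN(C)CCCCn1c(N)c(-c2nc3ccccc3s2)c2nc(C#N)c(C#N)nc21` carries 1,3-benzothiazol-2-yl in place of cyano on an aromatic carbon. Among the compounds with values here, no measured step shows the size of such a change. Within the data shown here, compound 2 gives 12200 nM, the only number in this assay, and the expectation rests on that value. The expected step is an at least 3.3-fold lower number from compound 1 to compound 3 (0.52 log units; beyond the scatter), toward stronger inhibition. Compound 3 is estimated at 15000 nM, with an expected range from 4000 nM to 50000 nM.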

Compound 3, half-maximal inhibitory concentration: 18700 nM
Compound 3: middle estimate off by 1.2-fold (0.10 log units), on the low side, within the range that was stated.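

In this assay, within the data shown here, 1,3-benzothiazol-2-yl in place of cyano on this aromatic carbon gives an at least 2.6-fold lower number from compound 1 to compound 3 (0.42 log units; beyond the scatter), which is the first step read at this position and shows that the larger fused group is accepted there without loss of activity. Compound 1 stands only as a limit, so the step has a lower bound and no exact size: the limit of > 50000 nM in this assay, at which 1 of the 3 values shown sits.

The compounds shown leave open how a phenyl ring or a carboxylic acid on this carbon would compare with 1,3-benzothiazol-2-yl. They also leave open whether the step holds when a longer chain replaces the 4-(dimethylamino)butyl group.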